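The source may report more compounds than this note shows. Statements on the series, on what has been measured and on what is new or still open speak of the compounds shown alone.

Measured compounds in this series:

compound 1, `COC(=O)c1c[nH]nc1/N=N/N(C)C`, 3.49
compound 2, `CCOC(=O)c1c[nH]nc1/N=N/N(C)C`, 3.35
compound 3, `CCN(C)/N=N/c1ccc(NC(N)=O)cc1`, 3.87

All three were run in a functional assay on L1210 cells (Mus musculus) for antiproliferative activity; a lower number here means a less potent compound, a higher number a more potent compound, by a factor of ten per unit of this negative logarithm. Compound 3 stands highest of the three numbers; compound 1 lies nearest to it and compound 2 furthest, and both of those gaps are beyond the scatter. Among the compounds with values here, compound 2 and compound 1 are within the scatter of each other: the step of a number 0.14 log units higher from compound 2 to compound 1 (within the scatter) is the one counted change (hydrogen in place of methyl on a saturated chain carbon bound to an oxygen next to a carbonyl group).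

Compound 4, `CN(C)/N=N/c1ccc(NC(N)=O)cc1`, is not yet measured. It differs from compound 3 by hydrogen in place of methyl on a saturated chain carbon bound to an amine nitrogen. The core of compound 3 and the core of compound 2 differ in more than one place; the difference between the two cores is not broken down here. The change from compound 3 to compound 4 is the same kind of change as that from compound 2 to compound 1, not the same: in the earlier pair the carbon carrying the methyl is bound to an oxygen next to a carbonyl group, in the new pair it is bound to an amine nitrogen.

Within the data shown here, only the one earlier instance is available, and it sits within the scatter. For compound 4 a step of about a number 0.08 log units higher from compound 3 to compound 4 (within the scatter) is therefore expected, set beside a number 0.14 log units higher from compound 2 to compound 1 (within the scatter), resting on the closeness of compound 2 and compound 1 and on the starting point of compound 3, 3.87. Compound 4 is estimated at 3.95, between 3.55 and 4.35.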

Compound 4, logarithm of the reciprocal of the active concentration, log(1/C): 3.97
Compound 4: the middle estimate sits 0.02 log units below what was measured, and the stated range covers the measured number.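

In this assay, hydrogen in place of methyl on a saturated chain carbon bound to an amine nitrogen gives a number 0.10 log units higher from compound 3 to compound 4 (within the scatter), so ethyl(methyl)amino and dimethylamino cannot be told apart on this core. Set beside the ester pair on the other core, the change reads alike: the same change on two cores in this assay, a number 0.14 log units higher (within the scatter) from compound 2 to compound 1 and a number 0.10 log units higher (within the scatter) from compound 3 to compound 4, 0.04 log units apart, within the scatter of two such steps This shows only that removing this one methyl produced no readable step on either core; it does not show a transferable effect, since neither step rises above the scatter, the carbon carrying the methyl is bound to a different atom in each pair, and two pairs are a thin basis for any rule across the series.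

Still open, from the compounds shown here alone, is whether a longer chain on the amine nitrogen, such as propyl or butyl, or an added hydroxyl on the ethyl group, would give a step beyond the scatter on the core of compound 3. The same question applies on the core of compound 1, where a longer chain on the ester oxygen or a carboxylic acid in place of the ester would show whether the flat reading holds beyond methyl and ethyl.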